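Extending the Amide Substituent of Compound 3

This account rests on a few compounds, and the source may have more. Where it says the series, first, only, none or still open, it means among the compounds named here.

Compound 3 `CCCn1c(SCc2cc([N+](=O)[O-])ccc2OC)nc2cc(NC(=O)NC(C)(C)C)cc(C(=O)NC)c21` gives 41 nM in an assay on isolated protein for inhibition of Gonadotropin-releasing hormone receptor (Homo sapiens) (on this read-out lower numbers stand for stronger inhibition and higher numbers for weaker inhibition), the lowest number among the three compounds measured. Compound 2 `CCCn1c(SCc2cc([N+](=O)[O-])ccc2OC)nc2cc(NC(=O)NC(C)(C)C)cc(C(=O)N(C)C)c21` gives 270 nM, and compound 1 `COc1ccc(C#N)cc1CSc1nc2cc(NC(=O)C3CC3)ccc2n1C(C)C` gives 570 nM. Among the measured compounds shown here, the one measured step that alters the amide-type nitrogen is a 6.6-fold lower number from compound 2 to compound 3 (0.82 log units; beyond the scatter), which shows that what sits on this nitrogen matters. Compound 4 `CCCn1c(SCc2cc([N+](=O)[O-])ccc2OC)nc2cc(NC(=O)NC(C)(C)C)cc(C(=O)NCc3ccncc3)c21` carries pyridin-4-yl in place of hydrogen on a saturated chain carbon bound to an amide-type nitrogen. For the measured compounds named here, this enlarges the group on that nitrogen instead of removing one, and no measured pair shows an addition of this kind, so the direction is uncertain and a moderate step either way would not surprise. Compound 4 is therefore expected to give 80 nM in this assay, within 20 nM to 400 nM. That expected outcome corresponds to a 2.0-fold higher number from compound 3 to compound 4 (0.29 log units; within the scatter).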

Compound 4, half-maximal inhibitory concentration: 61 nM
Estimate against measurement, compound 4: 1.3-fold (0.12 log units) above; low and high end bracket the measured number.
By their numbers in this assay, from the lowest: compounds 3 and 4 (each within the scatter of the next); then compound 2; then compound 1.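

In this assay, pyridin-4-yl can sit on the saturated chain carbon bound to the amide-type nitrogen with little consequence: the change gives a 1.5-fold higher number from compound 3 to compound 4 (0.17 log units; within the scatter), so this position accepts far more than a methyl. Compound 4 keeps the amide hydrogen, and the comparison with the dimethylamino group gives a 4.4-fold lower number from compound 2 to compound 4 (0.65 log units; beyond the scatter), in line with the earlier step at this nitrogen. No measurement available here explains either result.

From the compounds shown here alone, it remains open whether the ring nitrogen of the pyridine matters, which a plain phenyl ring on the same chain carbon would test. A longer chain between the amide-type nitrogen and the ring is equally unexplored in these compounds.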